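The source may hold more compounds than are shown below. What is called first, only, known or untested is meant among the compounds shown, and "the series" means these compounds.

Measured so far in a toxicity assay on Vero cells (Chlorocebus sabaeus) for cytotoxicity; a higher number here means that more compound is tolerated, a lower number that less compound is tolerated:
- compound 1 `O=C(/C=C/c1ccc([N+](=O)[O-])o1)c1ccc(Br)cc1`: 354000 nM
- compound 2 `O=C(/C=C/c1ccc([N+](=O)[O-])o1)c1ccco1`: 776000 nM
- compound 3 `O=C(/C=C/c1ccc([N+](=O)[O-])o1)c1cc2ccccc2oc1=O`: 360000 nM

Compound 1 and compound 3 give numbers within the scatter of each other, so nothing separates them. Compound 2 gives a higher number than compound 1 in this assay, a gap beyond the scatter, so compound 2 is the better tolerated of that pair.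

Compound 4 `O=C(/C=C/c1ccc([N+](=O)[O-])o1)c1ccc(OCc2cccc(Cl)c2)cc1` is not yet measured. It differs from compound 1 by (3-chlorobenzyl)oxy in place of bromo on an aromatic carbon. Among the compounds with values here, no step between two measured compounds matches this change, so there is nothing to set its size; the expectation is a step no larger than the scatter, if anything toward a lower number. Compound 4 is estimated at 250000 nM, with a range from 90000 nM to 700000 nM. This estimate corresponds to a step of a 1.4-fold lower number from compound 1 to compound 4 (0.15 log units; within the scatter).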

Compound 4, half-maximal cytotoxic concentration: 307000 nM
Compound 4: middle estimate off by 1.2-fold (0.09 log units), on the low side, and the stated range covers the measured number.
By their numbers in this assay, from the lowest: compounds 4, 1 and 3 (each within the scatter of the next); then compound 2.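

In this assay, (3-chlorobenzyl)oxy in place of bromo on the aromatic carbon para to a large group gives a 1.2-fold lower number from compound 1 to compound 4 (0.06 log units; within the scatter) and so does not separate the two compounds, although the entering group brings a further six-membered aromatic ring. This pair gives the first measured size for a change at this position, and at this position the larger group leaves tolerance where bromo had it. Going by these compounds, whether an amine or a carboxylic acid here would stay as close to compound 1 remains open, as does the contribution of the chlorine on the benzyl ring. No supporting evidence bears on the reason for this result.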